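Vero cell tolerance across three amide analogues

The source may report more compounds than this note shows. Statements on the series, on what has been measured and on what is new or still open speak of the compounds shown alone.

Compound 1 `COC(=O)c1cc(-c2cccc(NC(=O)c3ccc(/C=C/C(=O)c4cccc(F)c4)cc3)c2)on1`. In an ADME assay on Vero cells (Chlorocebus sabaeus) for cytotoxicity, read by MTT assay, with a stated time of 72 h (a higher number here means that more compound is tolerated, a lower number that less compound is tolerated), compound 1 gives > 40 ug/mL, which is a limit of the assay and not a number.
Compound 2 `COC(=O)c1cc(-c2cccc(NC(=O)c3ccc(C4OC4C(=O)c4ccc(Cl)cc4)cc3)c2)on1`. In this assay compound 2 gives > 20 ug/mL, again only a limit of the assay.

Compound 2 therefore stands at the limit of > 20 ug/mL in this assay, at which 1 of the 2 values shown sits, while the other measured value, that of compound 1, sits at the limit of > 40 ug/mL in this assay, at which 1 of the 2 values shown sits. Among the compounds with values here, because both values are limits, a step that the two limits leave unreadable from compound 1 to compound 2 cannot be read; the data say only that neither compound reached half-maximal cytotoxicity within the range tested.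

Compound 3 `COC(=O)c1cc(-c2cccc(NC(=O)c3ccc(/C=C/C(=O)c4ccc(OC)cc4)cc3)c2)on1` is not yet measured. It differs from compound 2 by 2-((4-methoxyphenyl)carbonyl)ethenyl in place of 3-((4-chlorophenyl)carbonyl)oxiran-2-yl on an aromatic carbon. Within the data shown here, the only measured step that could bear on this change is the one just described, and it is unreadable, so no size can be carried over. Compound 3 does carry an ethenyl-carbonyl linkage as in compound 1, whose value is also a limit. The expectation is that compound 3 is tolerated to a similar extent, with an estimated 50 ug/mL in this assay, range 20 ug/mL to 120 ug/mL. The expected step that the limit leaves unreadable from compound 2 to compound 3 is not beyond the scatter, and the result will most likely again be reported as a limit only.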

Compound 3, half-maximal cytotoxic concentration: > 10 ug/mL
Compound 3 gave a limit, no number (the forecaster's own chance of this, stated with the estimate: 80%); the middle value lies beyond the limit too.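

In this assay compound 3 gives > 10 ug/mL, a limit of the assay and not a number. Within the data shown here, compound 1 and compound 2 also stand only as limits, so no step among compound 1, compound 2 and compound 3 can be read. Open remains where the half-maximal cytotoxic concentration of each compound lies, and whether either exchanged group shifts it.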